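The source may hold more compounds than are shown below. What is called first, only, known or untested is meant among the compounds shown, and "the series" means these compounds.

Measured so far in a functional assay on A549 cells (Homo sapiens) for inhibition, read by MTT assay, with a stated time of 72 h; on this read-out higher numbers stand for weaker inhibition and lower numbers for stronger inhibition:
Compound 1 `CCOC(=O)C1=C(Nc2ccccc2)S/C(=C\c2ccc(O)c(O)c2)C1=O`: > 100000 nM
Compound 2 `CCOC(=O)C1=C(Nc2ccccc2)S/C(=C\c2ccc([N+](=O)[O-])c(O)c2)C1=O`: 19100 nM
Compound 3 `CCOC(=O)C1=C(Nc2ccccc2)S/C(=C\c2cc(OC)c(O)c(OC)c2)C1=O`: 19200 nM

Compound 1 gives > 100000 nM, which is a limit of the assay and not a number. Any step away from compound 1 therefore starts from a limit alone.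

Compound 4 `CCOC(=O)C1=C(Nc2ccccc2)S/C(=C\c2ccc[nH]2)C1=O` has not yet been measured. It differs from compound 1 as follows: 1H-pyrrol-2-yl in place of 3,4-dihydroxyphenyl on a double-bonded chain carbon bound to a double-bonded ring carbon. That is, 1H-pyrrol-2-yl stands in place of 3,4-dihydroxyphenyl on a double-bonded chain carbon bound to a double-bonded ring carbon.

Among the measured compounds shown here, one measured step bears on this change, an at least 5.2-fold lower number from compound 1 to compound 2 (0.71 log units; beyond the scatter), where nitro takes the place of hydroxy on an aromatic carbon. Compound 3 also lacks the 3,4-dihydroxyphenyl group, and compound 3 gives 19200 nM. Compound 4 gives up that group too, so a step of similar size towards a lower number is expected in this assay, though neither compound carries the incoming group.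

The estimated step is an at least 3.3-fold lower number from compound 1 to compound 4 (0.52 log units; beyond the scatter). For compound 4 the expected value is 30000 nM, with an estimated range of 10000 nM to 100000 nM.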

Compound 4, half-maximal inhibitory concentration: > 100000 nM
Compound 4: no number, only a limit; the forecaster's own chance of this, stated with the estimate: 25%; middle value at least 3.3-fold (0.52 log units) from the limit.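

No new step can be read between compound 1 and compound 4, because each gives only a limit of the assay and not a number: the limit of > 100000 nM in this assay, at which 2 of the 4 values shown sit.

The compounds shown leave open whether 1H-pyrrol-2-yl in place of 3,4-dihydroxyphenyl changes the result in this assay at all.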